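Cyclohexyl against ethoxy on the aromatic ether side chain

The source may hold more compounds than are shown below. What is called first, only, known or untested is meant among the compounds shown, and "the series" means these compounds.

Among the measured compounds shown here, compound 2 `Nc1ccc2cccc(OCCC3CCCCC3)c2n1` is the only member of the set with a number in an assay on cells with melanin-concentrating hormone receptor 1 (Homo sapiens) as the target, read by radioligand binding; a higher number here means a weaker inhibitor, a lower number a stronger inhibitor: compound 2 gives 808 nM. Compound 1 `COCCOCCOc1cccc2ccc(N)nc12` carries 2-methoxyethoxy at the same place and returns only a limit, > 2000 nM. Compound 3 `CC(CC(C)(C)C)Oc1cccc2cccnc12`, built on a different core, likewise returns only a limit, > 2000 nM. For the measured compounds named here, the one step with a measurable size is therefore an at least 2.4-fold lower number from compound 1 to compound 2 (0.39 log units; beyond the scatter), and even that rests on (the limit of > 2000 nM in this assay, at which 2 of the 3 values shown sit), so its true size is open-ended.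

Compound 4 `CCOCCOc1cccc2ccc(N)nc12` differs from compound 2 by ethoxy in place of cyclohexyl on a saturated chain carbon, two bonds along the chain from an oxygen on an aromatic ring. Ethoxy is the nearer relative of the 2-methoxyethoxy of compound 1 than of the cyclohexyl of compound 2, so the relevant comparison is the measured step in reverse: a return from compound 2 toward the ground that compound 1 occupies. Compound 4 is therefore expected to lose potency in this assay, with a fair chance that only a limit is reported. Compound 4 is estimated at 3000 nM, with a range from 1000 nM to 10000 nM. The estimate corresponds to an expected 3.7-fold higher number from compound 2 to compound 4 (0.57 log units; beyond the scatter), a step beyond the scatter in the weaker direction.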

Compound 4, half-maximal inhibitory concentration: > 2000 nM
Compound 4 was reported as a limit; the forecaster's own chance of this, stated with the estimate: 65%; the middle value lies beyond the limit too.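

Ethoxy in place of cyclohexyl on a saturated chain carbon, two bonds along the chain from an oxygen on an aromatic ring, gives an at least 2.4-fold higher number from compound 2 to compound 4 (0.39 log units; beyond the scatter) in this assay, so a second ringless ending containing oxygen now sits on the weaker side of compound 2, alongside the 2-methoxyethoxy of compound 1. Compound 1 and compound 4 are both reported only as limits, so the step between them cannot be read, and hydrogen in place of methoxy at the end of the chain shows no measurable effect in either direction. Among the compounds on the shared core, cyclohexyl remains the only ending at this place with a number, and the true size of the step away from it stays open-ended: the limit of > 2000 nM in this assay, at which 3 of the 4 values shown sit.

The cyclohexyl and ethoxy endings differ in both the ring and the chain oxygen, so these compounds cannot separate the two; a plain butyl chain or a tetrahydropyranyl ring at this place would bear directly on that question. Going by these compounds, whether an amine at the chain end or a longer chain carrying cyclohexyl would give a lower number than compound 2 also remains open.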